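The source may report more compounds than this note shows. Statements on the series, on what has been measured and on what is new or still open speak of the compounds shown alone.

Compound 1, `CNc1nc2ccccc2c(NCc2ccc(NC(=O)c3ccc(F)cc3)cc2)c1C#N`, in a functional assay on HCT-116 cells (Homo sapiens) for inhibition, read by luminescence and resazurin assay, with a stated time of 3 days (a lower number here means a stronger inhibitor, a higher number a weaker inhibitor), gives > 20000 nM, which is a limit of the assay and not a number. Compound 2, `CNc1nc(NCc2ccc(NC(=O)c3ccncc3)cc2)c2ccccc2n1`, gives > 20000 nM, again a limit. Compound 3, `CNc1nc(NCc2ccc(NS(=O)(=O)c3ccc(F)cc3)cc2)c2ccccc2n1`, gives 5300 nM.

Compound 2 therefore sits at the limit of > 20000 nM in this assay, at which 2 of the 3 values shown sit. Where it truly stands is not known; it is only known to be a weak inhibitor or inactive under these conditions, and compound 3 is the one compound with a measured number.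

Compound 4, `CN1CCN(c2nc(NCc3ccc(NC(=O)c4ccncc4)cc3)c3ccccc3n2)CC1`, differs from compound 2 in one place: 4-methylpiperazin-1-yl in place of methylamino on an aromatic carbon. For the measured compounds named here, the single measured step, an at least 3.7-fold lower number from compound 2 to compound 3 (0.57 log units; beyond the scatter), concerns a group on a nitrogen on an aromatic ring at the far end of the molecule, not the aromatic carbon of the shared core touched here, so it gives no guidance on size or direction for this exchange. Going by the values given here, no measured compound carries the 4-methylpiperazin-1-yl group. With nothing to point either way, and with compound 2 starting at a limit, compound 4 is expected to remain near that limit. The estimate for compound 4 is 20000 nM, within 5000 nM to 40000 nM. The step of a number no higher from compound 2 to compound 4 (the limit leaves the size open) is thus expected to be none beyond the scatter, with a real chance that only a limit is reported again.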

Compound 4, half-maximal inhibitory concentration: > 20000 nM
Compound 4 gave a limit, no number; the forecaster's own chance of this, stated with the estimate: 55%; the middle value sits exactly at the limit.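

Compound 2 and compound 4 each give only a limit of the assay and no number, so the step between them cannot be read: the limit of > 20000 nM in this assay, at which 3 of the 4 values shown sit.

The compounds shown leave open where compound 2 and compound 4 truly stand, and whether 4-methylpiperazin-1-yl in place of methylamino changes inhibition at all.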